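The compounds below may be only part of what the source reports. "The series", "measured", "known", "first", "only" and "open" are said of these compounds alone.

Compound 1 `COc1ccc([C@H]2Oc3cc(OC)c(OC)cc3[C@@H]2C)cc1O`: > 19.4 ug/mL
Compound 2 `COC1=CC(=O)C2(C(C)C(O)c3ccc(OC)c(O)c3)OC2C1=O`: 4.89 ug/mL

Of the compounds shown here, two have been measured in a functional assay on MDA-MB-231 cells (Homo sapiens) for cytotoxicity, read by MTT assay; on this read-out lower numbers stand for stronger inhibition and higher numbers for weaker inhibition. Compound 1 gives only a limit of the assay, > 19.4 ug/mL, so where it stands on the numbers is open-ended. It sits at the limit of > 19.4 ug/mL in this assay, at which 1 of the 2 values shown sits. Compound 2 gives 4.89 ug/mL in this assay. Among the compounds with values here, no step between measured compounds that differ in one place is available, so the two values show only that compound 2 returned a number while compound 1 did not.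

Compound 3 `COc1ccc([C@H]2Oc3cc(OC)c(O)cc3[C@@H]2C)cc1O` is the next compound to be measured in this assay. It differs from compound 1 in one place: hydrogen in place of methyl on an oxygen on an aromatic ring. Within the data shown here, nothing among the measured compounds tells what size this kind of change brings in this assay, and the starting point is itself only a limit. The step is therefore expected to be none beyond the scatter, a step that the limit leaves unreadable from compound 1 to compound 3. Compound 3 is expected to give about 20 ug/mL in this assay, within a range from 8 ug/mL to 50 ug/mL, and it may again be reported only as a limit.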

Compound 3, half-maximal inhibitory concentration: 7.7 ug/mL
Compound 3: the middle estimate sits 2.6-fold (0.41 log units) above what was measured, outside the stated range (below it).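

In this assay, within the data shown here, the change from methoxy to hydroxy on this aromatic ring gives an at least 2.5-fold lower number from compound 1 to compound 3 (0.40 log units; beyond the scatter), the first step between compounds that differ in one place. It shows that this one oxygen substituent on the core of compound 1 can move the read-out beyond the scatter, and that compound 3 returns a measured number where the parent gave none. On these data alone, the true size of the step stays open, since it is only a minimum and compound 1 remains a limit of the assay: the limit of > 19.4 ug/mL in this assay, at which 1 of the 3 values shown sits.

The compounds shown cannot say whether the hydroxy group itself matters or whether removing the methyl alone is enough, and an ethoxy group, an amine or a fluorine in the same place would help to separate the two. They also leave open whether the same change at the other methoxy groups of the core would bring a step of similar size, or any step at all.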